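Chloro to bromo on two related cores

The compounds below may be only part of what the source reports. "The series", "measured", "known", "first", "only" and "open" are said of these compounds alone.

Compound 1 `Cn1c(=O)c2[nH]c(SCC(=O)c3ccc(Cl)cc3)nc2n(C)c1=O` and compound 2 `Cn1c(=O)c2[nH]c(SCC(=O)c3ccc(Br)cc3)nc2n(C)c1=O` share one core. In a functional assay on PANC-1 cells (Homo sapiens) for inhibition, read by MTT assay, with a stated time of 48 h (a higher number here means a weaker inhibitor, a lower number a stronger inhibitor), compound 1 gives 7200 nM and compound 2 gives 7400 nM. The change bromo in place of chloro on an aromatic carbon made a 1.0-fold higher number from compound 1 to compound 2 (0.01 log units; within the scatter). Compound 3 `Cn1c(=O)[nH]c2nc(SC/C(=N/O)c3ccc(Cl)cc3)[nH]c2c1=O` carries a different core; the difference between the two cores is not broken down here. In this assay compound 3 gives 1700 nM, the lowest of the three numbers and beyond the scatter from both compound 1 and compound 2. Compound 4 `Cn1c(=O)[nH]c2nc(SC/C(=N/O)c3ccc(Br)cc3)[nH]c2c1=O` is not yet measured. It differs from compound 3 by bromo in place of chloro on an aromatic carbon, the same change as that seen between compound 1 and compound 2, at the same place. The step of a 1.1-fold higher number from compound 3 to compound 4 (0.02 log units; within the scatter) is expected to be small, resting on the step of a 1.0-fold higher number from compound 1 to compound 2 (0.01 log units; within the scatter) having stayed within the scatter. The estimate for compound 4 in this assay is 1800 nM, with a range from 850 nM to 3800 nM.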

Compound 4, half-maximal inhibitory concentration: 2100 nM
For compound 4 the middle estimate is 1.2-fold (0.07 log units) below the measured one, and the stated range covers the measured number.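

In this assay, 4-chlorophenyl to 4-bromophenyl on the core of compound 3 gives a 1.2-fold higher number from compound 3 to compound 4 (0.09 log units; within the scatter). Set beside the same change on the core of compound 1, the two steps do not differ: the same change on two cores in this assay, a 1.0-fold higher number (0.01 log units; within the scatter) from compound 1 to compound 2 and a 1.2-fold higher number (0.09 log units; within the scatter) from compound 3 to compound 4, 1.2-fold (0.08 log units) apart, within the scatter of two such steps. This shows that the change carried over between these two cores in this assay, but it rests on two pairs only and says nothing of other cores, other assays or why the steps agree.

Open, as far as these compounds go, is whether a methoxy group or an amine on the aromatic carbon that holds the halogen would also give matching steps on both cores. Also open, from the compounds shown here alone, is how the oxime and the carbonyl compare on a single core.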